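N-methylation of the indole carboxamide in a hydrazone series

The source may report more compounds than this note shows. Statements on the series, on what has been measured and on what is new or still open speak of the compounds shown alone.

Measured compounds:
compound 1, `COc1ccc2c(c1)c(/C=N\NC(=O)c1cn(C)c3ccccc13)cn2Cc1ccc(Cl)cc1`, > 100000 nM
compound 2, `COc1ccc2c(c1)c(/C=N\NC(=O)c1c[nH]c3ccccc13)cn2Cc1ccc(Cl)cc1`, > 100000 nM
compound 3, `COc1ccc(Cn2cc(/C=N\NC(=O)c3c[nH]c4ccccc34)c3ccc(F)cc32)cc1`, > 100000 nM

The series is read in a functional assay on LNCaP cells (Homo sapiens) for cytotoxicity; on this read-out lower numbers stand for stronger inhibition and higher numbers for weaker inhibition. Compound 1 gives > 100000 nM, which is a limit of the assay and not a number. Compound 2 likewise gives > 100000 nM, again a limit. Compound 3 also returns > 100000 nM, a limit as well. All three measured values therefore sit at the limit of > 100000 nM in this assay, at which 3 of the 3 values shown sit.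

Compound 2 and compound 1 differ by methyl in place of hydrogen on an aromatic nitrogen. The step that the two limits leave unreadable from compound 2 to compound 1 cannot be read, since both ends are limits.

Compound 3 carries a different core from compound 2; the difference between the two cores is not broken down here.

The unmeasured compound 4, `COc1ccc(Cn2cc(/C=N\NC(=O)c3cn(C)c4ccccc34)c3ccc(F)cc32)cc1`, is related to compound 3 by methyl in place of hydrogen on an aromatic nitrogen, the same change as that from compound 2 to compound 1. For compound 4 the step that the limit leaves unreadable from compound 3 to compound 4 is expected to be unreadable in the same way, resting on the fact that compound 3 sits at > 100000 nM and that the matched pair compound 2 to compound 1 gave no readable step. Compound 4 is accordingly estimated at 200000 nM, most likely reported only as a limit, with a range of 50000 nM to 1000000 nM in this assay.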

Compound 4, half-maximal inhibitory concentration: 9600 nM
For compound 4 the middle estimate is 21-fold (1.32 log units) above the measured one; measured number outside the range, below it.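

In this assay, for the compounds shown here, methyl in place of hydrogen on an aromatic nitrogen gives an at least 10-fold lower number from compound 3 to compound 4 (1.01 log units; beyond the scatter), the only readable step, and its full size stays unknown since compound 3 is held only as a limit of the assay. The same change on the core of compound 2 cannot be read, as both ends of that pair are limits, and the series as a whole rests heavily on such limits: the limit of > 100000 nM in this assay, at which 3 of the 4 values shown sit. The change therefore yields a measured value on one core and none on the other, which shows that its outcome in this assay does not simply carry from one core to the other, but a single readable pair gives no general size for the step and does not show which part of the core decides the outcome.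

From the compounds shown here alone, it remains open whether an ethyl group or a longer chain on the same aromatic nitrogen, or an amine or a carboxylic acid at the end of such a chain, would keep, lower or lose the value seen for compound 4. The compounds shown also leave open which of the several differences between the two cores matters, as no pair here separates them one at a time.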